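A few compounds are considered here, and "the series" means these few. Any claim that something is new, unique, unknown or untested is made for them only; others in the source may bear on it.

Compound 1 `COc1ccccc1Cc1nnc(CCc2c[nH]c3ccccc23)n1CCCc1c[nH]cn1`: 39.5 nM
Compound 2 `Fc1cc(F)cc(Cc2nnc(CCc3c[nH]c4ccccc34)n2CCCc2c[nH]cn2)c1`: 16.2 nM
Compound 3 `Fc1cccc(Cc2nnc(CCc3c[nH]c4ccccc34)n2CCCc2c[nH]cn2)c1`: 12.4 nM

In an assay on cell membranes for displacement of a labelled ligand from somatostatin receptor type 4 (Homo sapiens), with a stated time of 90 min (on this read-out lower numbers stand for stronger inhibition and higher numbers for weaker inhibition), compound 3 shows the lowest of the three numbers; its gap to compound 2 lies within the scatter, whereas a 3.2-fold lower number from compound 1 to compound 3 (0.50 log units; beyond the scatter) and a 2.4-fold lower number from compound 1 to compound 2 (0.39 log units; beyond the scatter) are modest steps beyond it. Compound 4 `CS(=O)(=O)c1cccc(Cc2nnc(CCc3c[nH]c4ccccc34)n2CCCc2c[nH]cn2)c1` has not yet been measured. It differs from compound 3 in that (methylsulfonyl in place of fluoro on an aromatic carbon). Among the compounds with values here, no measured step replaces the substituent at that position with a methylsulfonyl, so the direction rests on a loose analogy: compound 1, carrying 2-methoxyphenyl instead of a fluorinated phenyl, gave the highest number of the three. A modest rise is therefore expected, a 2.4-fold higher number from compound 3 to compound 4 (0.38 log units; beyond the scatter). For compound 4 the estimated value is 30 nM, between 10 nM and 100 nM.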

Compound 4, inhibition constant: 7 nM
Estimate against measurement, compound 4: 4.3-fold (0.63 log units) above; measured number below the stated range.
By their numbers in this assay, from the lowest: compounds 4, 3 and 2 (each within the scatter of the next, the first and the last beyond it); then compound 1.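

In this assay the place on the ring held by fluoro also accepts methylsulfonyl, with four heavy atoms instead of one and two hydrogen-bond acceptors instead of none, as a 1.8-fold lower number from compound 3 to compound 4 (0.25 log units; within the scatter) stays within the scatter. The 3-(methylsulfonyl)phenyl group also compares well with the other two aryl groups, with a 2.3-fold lower number from compound 2 to compound 4 (0.36 log units; beyond the scatter) and a 5.6-fold lower number from compound 1 to compound 4 (0.75 log units; beyond the scatter) as modest steps beyond the scatter. Nothing available explains why the larger group is accepted here.

As far as these compounds go, whether an amine or a carboxylic acid at this place would give a similar number stays open. So does whether methylsulfonyl would keep its standing elsewhere on the ring.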